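Working notes: fluoro to trifluoromethoxy, compound 1 to compound 4

The source may hold more compounds than are shown below. What is called first, only, known or untested is meant among the compounds shown, and "the series" means these compounds.

Measured in a functional assay on MDA-MB-231 cells (Homo sapiens) for antiproliferative activity, read by MTT assay, with a stated time of 24 h; a lower number here means a stronger inhibitor, a higher number a weaker inhibitor:
- compound 1 `O=C(O)CC(NS(=O)(=O)c1ccc(F)cc1)c1ccccc1`: 88400 nM
- compound 2 `O=C(O)CC(NS(=O)(=O)c1ccccc1Br)c1ccccc1`: > 100000 nM (a limit)
- compound 3 `O=C(O)CC(NS(=O)(=O)c1cc(F)cc(F)c1)c1ccccc1`: 79300 nM

Among the compounds with values here, compound 1 at 88400 nM and compound 3 at 79300 nM are the only two actual numbers, and they lie within the scatter of each other. The entry for compound 2, > 100000 nM, is a limit of the assay.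

Compound 4 `O=C(O)CC(NS(=O)(=O)c1ccc(OC(F)(F)F)cc1)c1ccccc1` keeps the core of compound 1 and carries trifluoromethoxy in place of fluoro on an aromatic carbon. Within the data shown here, the one measured step, an at least 1.1-fold higher number from compound 1 to compound 2 (0.05 log units; that floor lies within the scatter), puts 2-bromophenyl in place of 4-fluorophenyl on the sulfonyl sulfur. It is a different change, and its floor lies within the scatter, so it gives no sign of a real shift. No step beyond the scatter is therefore expected in this assay. The expected change is a 1.2-fold lower number from compound 1 to compound 4 (0.09 log units; within the scatter). A result at the limit of > 100000 nM in this assay, at which 1 of the 3 values shown sits, remains possible for compound 4. For compound 4 the estimated value is 72000 nM, with an expected range from 33000 nM to 130000 nM.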

Compound 4, half-maximal inhibitory concentration: > 100000 nM
Compound 4 was reported as a limit; the forecaster's own chance of this, stated with the estimate: 25%; middle value at least 1.3-fold (0.14 log units) away from the limit.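

In this assay compound 4 carries a limit, > 100000 nM, and not a number. Trifluoromethoxy in place of fluoro on an aromatic carbon, para to a large group, gives an at least 1.1-fold higher number from compound 1 to compound 4 (0.05 log units; that floor lies within the scatter); the true size of this change cannot be read, but the exchange brings no lower number at this position. Compound 4 joins compound 2 at a limit, so a second change to the sulfonyl-bound aromatic ring now ends there: the limit of > 100000 nM in this assay, at which 2 of the 4 values shown sit.

Still open, as far as these compounds go, is whether any group on this aromatic carbon moves the number beyond the scatter of the value for compound 1 in either direction. An amine or a methoxy group in place of fluoro would bear on that question, and would show whether a measurable number can be kept at this position in this assay.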